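The source may hold more compounds than are shown below. What is called first, only, known or untested is meant among the compounds shown, and "the series" means these compounds.

Compound 1 `O=C1COc2ccc(-c3cccc(NS(=O)(=O)c4ccc(F)cc4)c3)cc2N1`: > 40000 nM, a limit
Compound 2 `CC(C)N1C(=O)COc2ccc(-c3cccc(NS(=O)(=O)c4ccc(F)cc4)c3)cc21`: > 40000 nM, a limit
Compound 3 `O=C1COc2ccc(-c3cccc(NS(=O)(=O)c4ccc(F)cc4)c3)cc2N1c1ccc(Cl)cc1`: 27800 nM

Going by the values given here, in a functional assay on HepG2 cells (Homo sapiens) for antiproliferative activity, read by MTT assay, with a stated time of 72 h (a lower number here means a stronger inhibitor, a higher number a weaker inhibitor), compound 3 gives 27800 nM, the only true number. The remaining data are the limit of > 40000 nM in this assay, at which 2 of the 3 values shown sit.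

Compound 4 `O=C1COc2ccc(-c3cccc(NS(=O)(=O)c4ccc(F)cc4)c3)cc2N1C1CC1` carries cyclopropyl in place of 4-chlorophenyl on an amide-type nitrogen in a ring.

Among the compounds with values here, two measured steps bear on this change: an at least 1.4-fold lower number from compound 1 to compound 3 (0.15 log units; that floor lies within the scatter) and an at least 1.4-fold lower number from compound 2 to compound 3 (0.15 log units; that floor lies within the scatter). Both are floors within the scatter, while a step that the two limits leave unreadable from compound 1 to compound 2 adds nothing. Among the measured compounds, only compound 3 carries the 4-chlorophenyl, so losing it is expected to give a slightly higher number, not clearly beyond the scatter, and possibly only a limit. The expected change is a 1.4-fold higher number from compound 3 to compound 4 (0.16 log units; within the scatter). For compound 4 the estimated value is 40000 nM, with an expected range of 22000 nM to 80000 nM.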

Compound 4, half-maximal inhibitory concentration: > 40000 nM
Compound 4 ended at the assay's limit (the forecaster's own chance of this, stated with the estimate: 70%); the middle value lies on the limit itself.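

In this assay cyclopropyl in place of 4-chlorophenyl gives an at least 1.4-fold higher number from compound 3 to compound 4 (0.15 log units; that floor lies within the scatter) on the amide-type nitrogen in the ring. Going by these compounds alone, the steps among compound 1, compound 2 and compound 4 cannot be read, and 4-chlorophenyl remains the only group here with a true number. Compound 4 joins compound 1 and compound 2 at a limit, so cyclopropyl adds no measurable value at this position: the limit of > 40000 nM in this assay, at which 3 of the 4 values shown sit.

Whether the benzene ring or its chlorine accounts for the true number of compound 3 stays open. Unsubstituted phenyl or benzyl on this nitrogen would bear on that question.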